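The source may hold more compounds than are shown below. What is called first, only, known or untested is meant among the compounds shown, and "the series" means these compounds.

Compound 1, whose structure is `N#C[C@@H]1CCCN1C(=O)[C@@H]1C[C@H](CO)CN1`, is the starting point. Among the measured compounds shown here, in an assay on the whole organism (plasma, strain Sprague-Dawley) for inhibition of Dipeptidyl peptidase 4 (Rattus norvegicus), with a stated time of 6 h, at a dose of 1 mg/kg by the oral route (a lower number here means less inhibition, a higher number more inhibition at the dose given (going by the name of the read-out)), compound 1 gives 64%, the second highest of the three numbers known so far. Compound 2, with structure `CN(C)C(=O)[C@@H]1CN[C@H](C(=O)N2CCC[C@H]2C#N)C1`, gives 76% in this assay, and the change is a number 12 percentage points higher from compound 1 to compound 2 (beyond the scatter). Compound 3, with structure `N#C[C@@H]1CCCN1C(=O)[C@@H]1CCCN1`, gives 20%, so that the step is a number 44 percentage points lower from compound 1 to compound 3 (beyond the scatter), and from compound 2 the step is a number 56 percentage points lower from compound 2 to compound 3 (beyond the scatter). Both groups on that saturated ring carbon therefore matter greatly compared with bare hydrogen, while swapping one for the other shifts the number only modestly.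

Compound 4, with structure `CNC(=O)[C@@H]1CN[C@H](C(=O)N2CCC[C@H]2C#N)C1`, is not yet measured. It differs from compound 1 as follows: methylcarbamoyl in place of hydroxymethyl on a saturated ring carbon. The new group sits between those of compound 1 and compound 2 in size and make-up, and the step from compound 1 to compound 2 was modest, so a small rise or no change beyond the scatter is expected, giving a number 7 percentage points higher from compound 1 to compound 4 (within the scatter). The estimated value for compound 4 in this assay is 71%, within a range from 57% to 85%.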

Compound 4, a percentage reported as inhibition, in the whole organism at one dose (the size of the read-out at that dose, not a potency): 75%
Compound 4: the middle estimate sits 4 percentage points below what was measured; the range from low to high includes it.
By their numbers in this assay, from the lowest: compound 3; then compound 1; then compounds 4 and 2 (each within the scatter of the next).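

In this assay, the methyl on the amide-type nitrogen can give way to the amide hydrogen without a step that can be read (a number 1 percentage points lower from compound 2 to compound 4 (within the scatter)). Methylcarbamoyl on this saturated ring carbon also stands clear of hydroxymethyl (a number 11 percentage points higher from compound 1 to compound 4 (beyond the scatter)) and far clear of bare hydrogen (a number 55 percentage points higher from compound 3 to compound 4 (beyond the scatter)), so compound 2 and compound 4 now form a pair of carbamoyl compounds that match each other and both differ from compound 1 and compound 3. No measurement at hand offers an explanation for these steps.

Still open, going by these compounds, is how a plain carbamoyl group, with no methyl on its nitrogen, or a longer chain such as ethyl on that nitrogen, would read. On these data alone, it is equally open whether a carboxylic acid or an amine on the same ring carbon would match the carbamoyl groups or hydroxymethyl.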